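This account rests on a few compounds, and the source may have more. Where it says the series, first, only, none or still open, it means among the compounds named here.

Three compounds share one core, differing only in the aryl group on the carbonyl carbon of the acylurea. Compound 1 `CN(C(=O)NC(=O)c1cccc(C(F)(F)F)c1)c1nc(C(F)(F)F)c(C(=O)N/N=C/c2ccccc2C(F)(F)F)s1` gives 7.29 ug/mL in a functional assay on BCG823 cells (Homo sapiens) for inhibition, read by MTT assay, with a stated time of 72 h; on this read-out higher numbers stand for weaker inhibition and lower numbers for stronger inhibition; compound 2 `CN(C(=O)NC(=O)c1c(Cl)cccc1Cl)c1nc(C(F)(F)F)c(C(=O)N/N=C/c2ccccc2C(F)(F)F)s1` gives 4.12 ug/mL; compound 3 `CN(C(=O)NC(=O)c1cccc([N+](=O)[O-])c1)c1nc(C(F)(F)F)c(C(=O)N/N=C/c2ccccc2C(F)(F)F)s1` gives 3.97 ug/mL. Compound 3 shows the lowest number, but its gaps to the others are within the scatter. Compound 4 `CN(C(=O)NC(=O)c1ccc(C(F)(F)F)cc1)c1nc(C(F)(F)F)c(C(=O)N/N=C/c2ccccc2C(F)(F)F)s1` carries 4-(trifluoromethyl)phenyl in place of 3-nitrophenyl on a carbonyl carbon. The related steps of a 1.8-fold lower number from compound 1 to compound 3 (0.26 log units; within the scatter) and a 1.0-fold lower number from compound 2 to compound 3 (0.02 log units; within the scatter) are both within the scatter, so exchange of this aryl group has not moved the read-out beyond noise. Compound 1, the other trifluoromethylphenyl member, sits near compound 3. Compound 4 is therefore expected near the series mean, with a 1.4-fold higher number from compound 3 to compound 4 (0.14 log units; within the scatter) not beyond the scatter, at an estimated 5.5 ug/mL within 2.5 ug/mL to 12 ug/mL.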

Compound 4, half-maximal inhibitory concentration: 2.53 ug/mL
Estimate against measurement, compound 4: 2.2-fold (0.34 log units) above; measured number inside the range.
By their numbers in this assay, from the lowest: compounds 4, 3, 2 and 1 (each within the scatter of the next, the first and the last beyond it).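

In this assay, among the compounds shown here, exchanging 3-(trifluoromethyl)phenyl for 4-(trifluoromethyl)phenyl on this carbonyl carbon gives a 2.9-fold lower number from compound 1 to compound 4 (0.46 log units; beyond the scatter), the only step beyond the scatter, and it is modest. The steps of a 1.6-fold lower number from compound 3 to compound 4 (0.20 log units; within the scatter) and a 1.6-fold lower number from compound 2 to compound 4 (0.21 log units; within the scatter) stay within the scatter, so 4-(trifluoromethyl)phenyl cannot be ranked against 3-nitrophenyl or 2,6-dichlorophenyl. No measured property is available to account for the difference between the two trifluoromethylphenyl groups. Open, going by these compounds, is how a carboxylic acid or an amine on this phenyl ring, or a longer alkyl chain in place of the aryl group, would read out.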